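The source may report more compounds than this note shows. Statements on the series, on what has been measured and on what is new or still open speak of the compounds shown alone.

Measured so far in a functional assay on MCF7 cells (Homo sapiens) for cytotoxicity, read by MTT assay, with a stated time of 72 h; on this read-out lower numbers stand for stronger inhibition and higher numbers for weaker inhibition: compound 1 `Cc1cc(=O)n(-c2ccc(Br)cc2F)nc1C(=O)Nc1ccc(Oc2ncnc3sccc23)c(F)c1` gives 13300 nM; compound 2 `Cc1cc(=O)n(-c2cccc(F)c2)nc1C(=O)Nc1ccc(Oc2ncnc3sccc23)c(F)c1` gives 17300 nM.

Compound 2 holds the highest of the two numbers in this assay, though compound 1, its nearest neighbour, lies within the scatter of it. Compound 3 `Cc1ccc(-n2nc(C(=O)Nc3ccc(Oc4ncnc5sccc45)c(F)c3)c(C)cc2=O)cc1` differs from compound 2 by 4-methylphenyl in place of 3-fluorophenyl on an aromatic nitrogen. Going by the values given here, the one step that bears on this change, a 1.3-fold higher number from compound 1 to compound 2 (0.11 log units; within the scatter), also swapped the aryl group on the aromatic nitrogen and stayed within the scatter, so no step beyond the scatter is expected in this assay. Compound 3 is therefore estimated at 16000 nM, with a range from 7000 nM to 40000 nM. The expected step is a 1.1-fold lower number from compound 2 to compound 3 (0.03 log units; within the scatter).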

Compound 3, half-maximal inhibitory concentration: > 40000 nM
Compound 3: no number, only a limit; the forecaster's own chance of this, stated with the estimate: 10%; middle value at least 2.5-fold (0.39 log units) from the limit.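

The aryl group on the aromatic nitrogen is less indifferent in this assay than the earlier pair suggested: 4-methylphenyl in place of 3-fluorophenyl gives an at least 2.3-fold higher number from compound 2 to compound 3 (0.36 log units; beyond the scatter), and in place of 4-bromo-2-fluorophenyl it gives an at least 3.0-fold higher number from compound 1 to compound 3 (0.47 log units; beyond the scatter). Compound 3 carries only a limit of the assay, not a number, so both steps give only a minimum size: the limit of > 40000 nM in this assay, at which 1 of the 3 values shown sits.

The compounds shown leave open whether the methyl group itself matters or the absence of any halogen on the ring. They also leave open how an unsubstituted phenyl or a 4-aminophenyl would behave on this nitrogen.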